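Working notes: hydroxy to bromo on the shared core

The compounds below may be only part of what the source reports. "The series", "measured", "known", "first", "only" and "open" are said of these compounds alone.

Three compounds have numbers in a functional assay on A549 cells (Homo sapiens) for cytotoxicity, with a stated time of 48 h; a lower number here means a stronger inhibitor, a higher number a weaker inhibitor:

Compound 1, `Cc1cccc2c(=O)cc(/C=C/[S+](C)[O-])oc12`, gives 1700 nM.
Compound 2, `C[S+]([O-])/C=C/c1cc(=O)c2cc(O)ccc2o1`, gives 10500 nM.
Compound 3, `Cc1cccc2oc(/C=C/[S+](C)[O-])cc(=O)c12`, gives 1300 nM.

Compound 2 stands with the highest number of the three. Compound 1 and compound 3 both give lower numbers, and in each case the gap to compound 2 lies beyond the scatter, so compound 2 is the weakest inhibitor among the measured compounds. Among the measured compounds shown here, compound 1 and compound 3 carry a methyl on the core where compound 2 carries a hydroxy, and no pair of measured compounds differs in a single place, so no measured step isolates any one change.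

Compound 4, `C[S+]([O-])/C=C/c1cc(=O)c2cc(Br)ccc2o1`, has not yet been measured. It differs from compound 2 as follows: bromo in place of hydroxy on an aromatic carbon. For the measured compounds named here, no measured step carries this change, so its size is not known from the data. A step downward beyond the scatter is nevertheless expected for compound 4, because compound 1 gives 1700 nM and compound 3 gives 1300 nM without the hydroxy that compound 2 carries. For compound 4 the expected number is 2500 nM, with a range of 800 nM to 8000 nM. This expectation corresponds to a 4.2-fold lower number from compound 2 to compound 4 (0.62 log units; beyond the scatter).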

Compound 4, half-maximal inhibitory concentration: 1100 nM
Beside the measured number, compound 4's estimate is 2.3-fold (0.36 log units) above it, within the range that was stated.
By their numbers in this assay, from the lowest: compounds 4, 3 and 1 (each within the scatter of the next); then compound 2.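

Among the compounds shown here, on the shared core, the aromatic carbon that holds the hydroxy in compound 2 now has a step of its own: in this assay, bromo in place of hydroxy gives a 9.5-fold lower number from compound 2 to compound 4 (0.98 log units; beyond the scatter) as a change in one place only, which the earlier compounds could not provide. The hydroxy, with the hydrogen-bond donor and acceptor counted for it, is thus not required at this carbon for inhibition in this assay, and the number at this position moves by more than the usual scatter when the group is exchanged. No measurement offered alongside these numbers bears on why the step occurs.

A single pair cannot separate what the departure of hydroxy contributes from what the arrival of bromo contributes, and a plain hydrogen, a methoxy group or an amine on the same aromatic carbon would divide the two. Going by these compounds, it also remains open whether the same exchange would give a step of similar size on the methyl-bearing cores of compound 1 and compound 3.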